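A few compounds are considered here, and "the series" means these few. Any claim that something is new, unique, unknown or untested is made for them only; others in the source may bear on it.

Measured so far:
compound 1, `Cc1cccc(C#CCNc2cccc(Cl)c2)n1`, 174 nM
compound 2, `Cc1cccc(C#CCSc2cccc(Cl)c2)n1`, 43 nM
compound 3, `Cc1cccc(C#CC(C)Nc2cccc(Cl)c2)n1`, 709 nM

All three values come from a functional assay for inhibition of metabotropic glutamate receptor 5 (Homo sapiens), read by FLIPR and calcium flux; on this read-out lower numbers stand for stronger inhibition and higher numbers for weaker inhibition. Compound 2 gives the lowest number of the three, and its nearest neighbour is compound 1 at 174 nM. The difference between the cores of compound 1 and compound 2 is not broken down here. Within the compound 1 core, the change methyl in place of hydrogen on a saturated chain carbon bound to a nitrogen on an aromatic ring and a triple-bonded carbon produced a 4.1-fold higher number from compound 1 to compound 3 (0.61 log units; beyond the scatter), a modest loss.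

Compound 4, `Cc1cccc(C#CC(C)Sc2cccc(Cl)c2)n1`, has not been measured in this assay. It differs from compound 2 by methyl in place of hydrogen on a saturated chain carbon bound to a sulfur and a triple-bonded carbon. The two places are not the same word for word: in compound 1 the carbon is bound to a nitrogen on an aromatic ring, in compound 2 it is bound to a sulfur, so this is the same kind of change rather than the same one. The step from compound 2 to compound 4 is expected to be about a 4.0-fold higher number from compound 2 to compound 4 (0.60 log units; beyond the scatter), set beside a 4.1-fold higher number from compound 1 to compound 3 (0.61 log units; beyond the scatter), because compound 3 at 709 nM sits well above compound 1. Compound 4 is accordingly expected near 170 nM, between 60 nM and 500 nM.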

Compound 4, half-maximal inhibitory concentration: 118 nM
Compound 4: the middle estimate sits 1.4-fold (0.16 log units) above what was measured, and the stated range covers the measured number.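

The methyl in place of hydrogen on a saturated chain carbon bound to a sulfur and a triple-bonded carbon gives a 2.7-fold higher number from compound 2 to compound 4 (0.44 log units; beyond the scatter) in this assay and so weakens inhibition on the core of compound 2 as well. Set beside the earlier step, the change carries over from one core to the other without a measurable difference in size: the same change on two cores in this assay, a 4.1-fold higher number (0.61 log units; beyond the scatter) from compound 1 to compound 3 and a 2.7-fold higher number (0.44 log units; beyond the scatter) from compound 2 to compound 4, 1.5-fold (0.17 log units) apart, within the scatter of two such steps. This agreement rests on two cores only, so it does not show that the step would hold on any other core, and it gives no reason for the loss.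

The compounds shown leave open what a larger group on the same chain carbon would do, such as an ethyl or a second methyl, and whether an oxygen in place of the sulfur or the nitrogen would keep the same step. Also open, as far as these compounds go, is whether a fluorine or a methoxy in place of the chlorine would leave the methyl step unchanged.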